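Swapping the acetyl ester for a chloropyridinyl ester

A few compounds are considered here, and "the series" means these few. Any claim that something is new, unique, unknown or untested is made for them only; others in the source may bear on it.

Compound 2 `CC(=O)Oc1ccccc1C(=O)O[C@H]1CO[C@H]2[C@@H]1OC[C@H]2OC(C)=O` carries an acetyl ester on its shared core. In an ADME assay on a cell-free system (plasma, Homo sapiens) for metabolic stability, with Plasma (Rattus norvegicus) as the target, read by HPLC, at pH 7.4 (on this read-out lower numbers stand for a shorter-lived compound and higher numbers for a longer-lived compound), compound 2 gives 0.0095 h. Going by the values given here, of the three numbers measured so far, compound 2 sits at the low end: compound 1 `CC(=O)Oc1ccccc1C(=O)O[C@H]1CO[C@H]2[C@@H]1OC[C@H]2OC(=O)c1ccnn1C` gives 0.0642 h, a step beyond the scatter away, while compound 3 `CC(=O)Oc1ccccc1C(=O)O[C@H]1CO[C@H]2[C@@H]1OC[C@H]2OC(=O)c1ccccc1C` gives 0.0138 h, within the scatter of compound 2. Compound 4 `CC(=O)Oc1ccccc1C(=O)O[C@H]1CO[C@H]2[C@@H]1OC[C@H]2OC(=O)c1cnccc1Cl` has not yet been measured. It differs from compound 2 by 4-chloropyridin-3-yl in place of methyl on a carbonyl carbon. Among the compounds with values here, two measured steps bear on this change, since each replaces the same methyl on that carbonyl carbon with a ring. The step of a 1.5-fold higher number from compound 2 to compound 3 (0.16 log units; within the scatter) shows that a 2-methylphenyl ring in place of methyl left the number essentially where it was. The step of a 6.8-fold lower number from compound 1 to compound 2 (0.83 log units; beyond the scatter), read in reverse, shows that a 1-methyl-1H-pyrazol-5-yl ring in place of methyl goes with a longer-lived compound. The 4-chloropyridin-3-yl ring, one six-membered aromatic ring with 1 hetero atom, is neither of the rings already tested, so a step somewhere between those two outcomes is expected, leaning upward: a 2.6-fold higher number from compound 2 to compound 4 (0.42 log units; beyond the scatter) is the expected change. Compound 4 is therefore estimated at 0.025 h, with a likely range from 0.008 h to 0.08 h.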

Compound 4, half-life: 0.0322 h
Beside the measured number, compound 4's estimate is 1.3-fold (0.11 log units) below it; the range from low to high includes it.
By their numbers in this assay, from the lowest: compounds 2 and 3 (each within the scatter of the next); then compounds 4 and 1 (each within the scatter of the next).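

In this assay, the step of a 3.4-fold higher number from compound 2 to compound 4 (0.53 log units; beyond the scatter) means that a second ring in place of methyl on this carbonyl carbon goes with a longer-lived compound, after the 1-methyl-1H-pyrazol-5-yl ring of compound 1. The step of a 2.3-fold higher number from compound 3 to compound 4 (0.37 log units; beyond the scatter) adds that simply having a ring here does not settle the outcome, and compound 3 is the one that goes against a rule of "ring beats methyl", since its 2-methylphenyl ring stays within the scatter of compound 2. The step of a 2.0-fold lower number from compound 1 to compound 4 (0.30 log units; within the scatter) leaves the two nitrogen-bearing rings of these compounds indistinguishable on this read-out, although they differ in ring size, and no measurement shown here explains any of these differences.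

On these data alone, what the chlorine on the ring of compound 4 contributes remains open, as does whether a plain pyridin-3-yl ring would fall with compound 4 or with compound 3. Also open, as far as these compounds go, is how a longer carbon chain in place of methyl, or a ring carrying an amine or a carboxylic acid, would behave at this carbonyl carbon.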